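The source may hold more compounds than are shown below. What is called first, only, known or untested is meant among the compounds shown, and "the series" means these compounds.

In a functional assay on HOS-TE85 cells (Homo sapiens) for cytotoxicity, read by fluorescence and resazurin assay, with a stated time of 72 h (a lower number here means a stronger inhibitor, a higher number a weaker inhibitor), three compounds with a shared core have been measured. Compound 1 `Nc1nc(Nc2ccc(S(N)(=O)=O)cc2)sc1C(=O)c1ccccc1[N+](=O)[O-]` gives 3000 nM and compound 2 `Nc1nc(Nc2ccc(S(N)(=O)=O)cc2)sc1C(=O)c1cccc(F)c1` gives 2200 nM, so these two stand together within the scatter. Compound 3 `Nc1nc(Nc2ccc(S(N)(=O)=O)cc2)sc1C(=O)c1ccc(S(N)(=O)=O)cc1` gives > 10000 nM, which is a limit of the assay and not a number.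

Compound 4 `Nc1cccc(C(=O)c2sc(Nc3ccc(S(N)(=O)=O)cc3)nc2N)c1` departs from compound 2 by one change, amino in place of fluoro on an aromatic carbon. For the measured compounds named here, the one measured step that bears on this, a 1.4-fold lower number from compound 1 to compound 2 (0.13 log units; within the scatter), also exchanges the group on the ring held by the carbonyl, and it stays within the scatter. On that single step, no shift beyond the scatter is expected in this assay. The expected step of a 1.4-fold higher number from compound 2 to compound 4 (0.13 log units; within the scatter) is an estimate only. For compound 4 the estimated value is 3000 nM, with an expected range from 1000 nM to 9000 nM.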

Compound 4, half-maximal inhibitory concentration: > 10000 nM
Compound 4: no number, only a limit; the forecaster's own chance of this, stated with the estimate: 15%; middle value at least 3.3-fold (0.52 log units) from the limit.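

In this assay, for the compounds shown here, swapping the group on the ring held by the carbonyl had so far stayed within the scatter, but this position is not indifferent to the group it carries: the change from 3-fluorophenyl to 3-aminophenyl gives an at least 4.5-fold higher number from compound 2 to compound 4 (0.65 log units; beyond the scatter), and the comparison with the nitro compound gives an at least 3.3-fold higher number from compound 1 to compound 4 (0.52 log units; beyond the scatter). Both steps point to a weaker inhibitor. The value of compound 4 is a limit and not a number, so each step gives only a smallest size: the limit of > 10000 nM in this assay, at which 2 of the 4 values shown sit.

From the compounds shown here alone, how far compound 4 really lies from the others stays open. So does how a hydroxyl, a methyl or a carboxylic acid would read on that same aromatic carbon.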